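A few compounds are considered here, and "the series" means these few. Any claim that something is new, unique, unknown or untested is made for them only; others in the source may bear on it.

Compound 1 `COc1cc(-c2cc(/C=C/C(=O)c3ccc(N)cc3)[nH]n2)cc(OC)c1OC` was tested in a functional assay on K562 cells (Homo sapiens) for cytotoxicity, read by sulforhodamine B assay, with a stated time of 48 h, tested at 10 uM (a lower number here means a stronger effect, a higher number a weaker effect of the compound at the concentration tested), and gives 2%. Among the three measured compounds this is the second highest number; the nearest is compound 2 `COc1ccc(-c2cc(/C=C/C(=O)c3ccc(OC)c(OC)c3)[nH]n2)cc1`, which gives 1%, and the furthest is compound 3 `COc1ccc(-c2cc(/C=C/C(=O)c3ccc(N)cc3)[nH]n2)cc1OC`, which gives 3%. Among the compounds with values here, both gaps lie within the scatter, and the one measured step, a number 1 percentage points higher from compound 1 to compound 3 (within the scatter), is also within it, so the three compounds cannot be told apart on these numbers.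

Compound 4 `COc1ccc(C(=O)/C=C/c2cc(-c3cc(OC)c(OC)c(OC)c3)n[nH]2)cc1OC` has not been measured yet. It differs from compound 1 in one place: 3,4-dimethoxyphenyl in place of 4-aminophenyl on a carbonyl carbon. Within the data shown here, no measured step bears on this change directly; the step from compound 1 to compound 3 alters a different part of the molecule. Compound 2, however, already carries a 3,4-dimethoxyphenyl on a carbonyl carbon and gives 1%, and every measured value sits at the low end of the scale. The estimated step of no change at the digits printed from compound 1 to compound 4 (within the scatter) is therefore expected to stay within the scatter. For compound 4 the value in this assay is estimated at 2%, with a range from -6% to 10%.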

Compound 4, a percentage reported as activity, at one concentration (the size of the read-out at that concentration, not a potency): -13%
Beside the measured number, compound 4's estimate is 15 percentage points above it, outside the stated range (below it).
By their numbers in this assay, from the lowest: compound 4; then compounds 2, 1 and 3 (each within the scatter of the next).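

In this assay, the change on the carbonyl carbon gives a number 15 percentage points lower from compound 1 to compound 4 (beyond the scatter), the first step shown that lies beyond the scatter, so replacing the group at this position can shift the read-out. The 3,4-dimethoxyphenyl group does not set the number alone: compound 2 carries it on the same carbonyl carbon and gives 1%, whereas compound 4 gives -13%, so the rest of the molecule also appears to matter. No measurement shown explains why the number falls.

The compounds shown leave open whether both methoxy groups are needed, since no compound here carries a plain phenyl or a 3,4-dihydroxyphenyl on the carbonyl carbon. They also leave open whether a longer chain in place of either methoxy would take the number lower still.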